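Removing an aromatic bromine from a sulfonylindole piperazine series

The source may report more compounds than this note shows. Statements on the series, on what has been measured and on what is new or still open speak of the compounds shown alone.

Compound 1 `CCN1CCN(c2cn(S(=O)(=O)c3ccc(C(C)C)cc3)c3ccccc23)CC1` gives 8.6 nM in an assay on HeLa cells for displacement of a labelled ligand from 5-hydroxytryptamine receptor 6 (Homo sapiens); on this read-out higher numbers stand for weaker inhibition and lower numbers for stronger inhibition. Compound 2 `CCN1CCN(c2cn(S(=O)(=O)c3ccc(C(C)C)cc3)c3ccc(Br)cc23)CC1`, which carries a bromo on its fused ring, gives 30.1 nM in this assay, and the step of a 3.5-fold lower number from compound 2 to compound 1 (0.54 log units; beyond the scatter) follows from hydrogen in place of bromo on an aromatic carbon. Compound 3 `CN1CCN(c2cn(S(=O)(=O)c3ccccc3Br)c3ccccc23)CC1` gives 15.2 nM in this assay; the difference between the core of compound 3 and that of compound 2 is not broken down here. Compound 4 `CN1CCN(c2cn(S(=O)(=O)c3ccccc3)c3ccccc23)CC1` has not yet been measured. It differs from compound 3 by hydrogen in place of bromo on an aromatic carbon, the same kind of change as between compound 2 and compound 1, but at a different place: here the bromo sits ortho to a large group on a six-membered aromatic ring of carbon only, not on the fused ring system. Because a 3.5-fold lower number from compound 2 to compound 1 (0.54 log units; beyond the scatter) points toward a lower number on loss of the bromo, compound 4 is expected to give 6 nM in this assay, a step of a 2.5-fold lower number from compound 3 to compound 4 (0.40 log units; beyond the scatter), with an expected range from 2 nM to 20 nM.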

Compound 4, inhibition constant: 15.9 nM
Compound 4: the middle estimate sits 2.7-fold (0.42 log units) below what was measured; measured number inside the range.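

In this assay, hydrogen in place of the bromo on the 2-bromophenyl group gives a 1.0-fold higher number from compound 3 to compound 4 (0.02 log units; within the scatter). The step seen on the fused ring therefore does not carry over to this place and core, and the two steps differ: the same change on two cores in this assay, a 3.5-fold lower number (0.54 log units; beyond the scatter) from compound 2 to compound 1 and a 1.0-fold higher number (0.02 log units; within the scatter) from compound 3 to compound 4, 3.7-fold (0.56 log units) apart, beyond the scatter of two such steps. The two pairs differ both in where the bromo sits and in the rest of the core, and these data do not separate the two, nor do two pairs give a rule for the series.

Going by these compounds, it remains open whether a chlorine, a methoxy group or an amine on that same aromatic carbon gives a step beyond the scatter in this assay. Also open, on these data alone, is what a bromo on the fused ring does on the core of compound 4.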